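The source may hold more compounds than are shown below. What is called first, only, known or untested is meant among the compounds shown, and "the series" means these compounds.

Measured compounds in this series:

compound 1, `COC(=O)/C=C/C(=O)c1ccccc1`: 2.24
compound 2, `O=C(O)/C=C/C(=O)c1ccccc1`: 1.94
compound 3, `COC(=O)/C=C/C(=O)c1cccnc1`: 0.056

In a physicochemical assay for lipophilicity (a higher number here means a more lipophilic compound, a lower number a more polar compound), compound 1 gives 2.24 and compound 2 gives 1.94. The change between them is hydrogen in place of methyl on an oxygen next to a carbonyl group and it produced a number 0.30 log units lower from compound 1 to compound 2 (within the scatter). Compound 3 gives 0.056 and stands lowest of the three; its distance to compound 2 and to compound 1 lies beyond the scatter in both cases. How the core of compound 3 differs from the core of compound 1 is not broken down here.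

Compound 4, `O=C(O)/C=C/C(=O)c1cccnc1`, is not yet measured in this assay. The change from compound 3 to compound 4 is hydrogen in place of methyl on an oxygen next to a carbonyl group. Within the data shown here, this is the same change as the one from compound 1 to compound 2: the group that leaves, the atom that enters and the place where it happens agree word for word. Among the compounds shown it occurs nowhere else, so the single measured step is the only guide available.

On that basis the step expected from compound 3 to compound 4 is a number 0.30 log units lower from compound 3 to compound 4 (within the scatter), resting on the step seen from compound 1 to compound 2, a number 0.30 log units lower from compound 1 to compound 2 (within the scatter), a step that itself sits within the scatter. Because of 0.056 for compound 3, compound 4 is estimated at -0.24. Among the measured compounds shown here, with only one prior example of this change, the range is kept wide: compound 4 is expected to fall between -0.75 and 0.25.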

Compound 4, partition coefficient: 0.26
The estimate for compound 4 lay 0.50 log units below the measured number, and the stated range ends below it.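

In this assay the change from methoxycarbonyl to carboxy reads a number 0.20 log units higher from compound 3 to compound 4 (within the scatter) on the core of compound 3 and a number 0.30 log units lower from compound 1 to compound 2 (within the scatter) on the core of compound 1 . What carries across these two cores is only a step that stays within the scatter each time; the printed signs differ, but that gives no ground for assigning a direction to the change on either core. This does not show that the change is without any effect or that its size is fixed across the series, and no measurement bearing on the reason for either step is at hand.

Open is whether the same reading holds on a further core, as the pair of compound 1 and compound 2 and the pair of compound 3 and compound 4 are the only two examples of this change shown here. Equally open, as far as these compounds go, is how this assay would read with a longer chain such as ethyl in place of methyl on an oxygen next to a carbonyl group, or with an amide in place of the carboxy group, on either core.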